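A few compounds are considered here, and "the series" means these few. Any claim that something is new, unique, unknown or untested is made for them only; others in the source may bear on it.

Compound 1 `Oc1nc2nonc2nc1Nc1ccc(OC(F)(F)F)c(Cl)c1` in an assay on mitochondria from L6 cells (Rattus norvegicus) for activation, with a stated time of 90 min (on this read-out higher numbers stand for an effect only at larger amounts of compound and lower numbers for an effect already at smaller amounts), gives 3000 nM.
Compound 2 `Oc1nc2nonc2nc1Nc1ccc(SC(F)(F)F)cc1` in this assay gives 1400 nM.
Compound 3 `CCCCCCc1ccc(Nc2nc3nonc3nc2O)c(F)c1` in this assay gives 3300 nM.

Compound 2 has the lowest of these three numbers. Its nearest neighbour is compound 1, whose number is higher by a step that lies beyond the usual scatter, and compound 3 stands further away still, also beyond the scatter. The three compounds share one core and differ only in the groups carried on the attached benzene ring, so no two of them differ in a single place, and no measured step can be read off directly.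

Compound 4 `Oc1nc2nonc2nc1Nc1ccc(C(F)(F)F)cc1` is the compound still to be measured. It changes compound 2 in one spot:
trifluoromethyl in place of (trifluoromethyl)sulfanyl on an aromatic carbon
Going by the values given here, the group that enters is the one carried by the group that leaves, with the sulfur atom gone. Among the compounds with values here, a change of this kind could shift the number in either direction in this assay; with no measured pair of this type to lean on, the expectation is a modest rise in the number, of about a 1.8-fold higher number from compound 2 to compound 4 (0.25 log units; within the scatter), which may not clear the scatter. Compound 4 is therefore expected to give about 2500 nM, within a range from 900 nM to 7000 nM.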

Compound 4, half-maximal effective concentration: 10400 nM
For compound 4 the middle estimate is 4.2-fold (0.62 log units) below the measured one; the whole stated range lies below it.
By their numbers in this assay, from the lowest: compound 2; then compounds 1 and 3 (each within the scatter of the next); then compound 4.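

Going by these compounds alone, compound 2 and compound 4 form the first pair here that differs in only one place, so the effect of a single change can finally be read directly. In this assay, removing the sulfur atom from the group on the aromatic carbon para to a large group gives a 7.4-fold higher number from compound 2 to compound 4 (0.87 log units; beyond the scatter), so a larger amount of compound is needed for the same effect, and this one atom clearly matters at this position. No measurement at hand explains the step.

The compounds shown leave open how a group without fluorine, such as methylsulfanyl, an amine or a carboxylic acid, would behave at this position. They also leave open whether removing the sulfur atom would have a similar effect with other groups on the benzene ring.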